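The compounds below may be only part of what the source reports. "The series", "measured", "known", "first", "only" and "open" are said of these compounds alone.

Measured so far in an assay on Sf9 cells for inhibition of protein deacetylase HDAC6 (Homo sapiens), read by fluorescence, with a stated time of 40 min, tested at 100 nM; a higher number here means more inhibition at the concentration tested (going by the name of the read-out), a lower number less inhibition:
- compound 1 `CC(C)c1ccc(-n2nc(-c3ccccc3)nc2CNc2ccc(C(=O)NO)cc2)cc1`: 52.6%
- compound 2 `O=C(NO)c1ccc(NCc2nc(-c3ccccn3)nn2-c2ccccc2)cc1`: 58.6%
- compound 3 `O=C(NO)c1ccc(NCc2nc(-c3ccccc3)nn2-c2ccc(F)cc2)cc1`: 67.6%

Compound 3 gives the largest number of the three; compound 2 sits within the scatter of it, compound 1 beyond it. Compound 4 `O=C(NO)c1ccc(NCc2nc(-c3ccccc3)nn2-c2ccccc2)cc1` differs from compound 3 by hydrogen in place of fluoro on an aromatic carbon. The only step shown at this position is a number 15 percentage points higher from compound 1 to compound 3 (beyond the scatter), in which a large group gave way to fluoro. Within the data shown here, no measured pair compares fluoro with hydrogen, so that step bears on compound 4 only indirectly. A small loss, or nothing beyond the scatter, is expected for compound 4, a step of a number 7.6 percentage points lower from compound 3 to compound 4 (within the scatter). Compound 4 is therefore estimated at 60%, with a range from 45% to 75%.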

Compound 4, a percentage reported as inhibition, at one concentration (the size of the read-out at that concentration, not a potency): 72.6%
For compound 4 the middle estimate is 12.6 percentage points below the measured one, within the range that was stated.
By their numbers in this assay, from the lowest: compounds 1, 2, 3 and 4 (each within the scatter of the next, the first and the last beyond it).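

In this assay, 4-fluorophenyl to phenyl gives a number 5 percentage points higher from compound 3 to compound 4 (within the scatter) and so does not separate hydrogen from fluoro at this position, whereas isopropyl separates from both: hydrogen in its place gives a number 20 percentage points higher from compound 1 to compound 4 (beyond the scatter). At the other aromatic substituent, phenyl in place of pyridin-2-yl gives a number 14 percentage points higher from compound 2 to compound 4 (beyond the scatter), so that change also registers beyond the scatter. Nothing at hand accounts for these steps.

Going by these compounds, whether a methoxy group, an amine or a carboxylic acid at this position stays level with hydrogen remains open. So does whether the pyridin-2-yl step holds with fluoro on the other ring.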